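Compound 2 to compound 3 in a 5-HT6 binding series

A few compounds are considered here, and "the series" means these few. Any claim that something is new, unique, unknown or untested is made for them only; others in the source may bear on it.

Within the data shown here, compound 2 `CN(C[C@@H]1CCCc2cc(S(=O)(=O)c3cccc(F)c3)ccc21)C(N)=O` gives 39.8 nM in an assay on isolated protein for displacement of a labelled ligand from 5-hydroxytryptamine receptor 6 (Homo sapiens) (a lower number here means a stronger inhibitor, a higher number a weaker inhibitor), and holds the highest number of the two measured so far; the only neighbour is compound 1 `COCCNC[C@@H]1CCCc2cc(S(=O)(=O)c3cccc(F)c3)ccc21`, which in this assay gives 0.251 nM. Among the measured compounds shown here, the one measured step, a 160-fold higher number from compound 1 to compound 2 (2.20 log units; beyond the scatter), shows that exchanging the basic (2-methoxyethyl)amino for the neutral carbamoyl(methyl)amino carried a large cost.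

Compound 3 `CC(C)(O)C(=O)NC[C@@H]1CCCc2cc(S(=O)(=O)c3cccc(F)c3)ccc21` is not yet measured. It differs from compound 2 by ((1-hydroxy-1-methylethyl)carbonyl)amino in place of carbamoyl(methyl)amino on a saturated chain carbon bound to a saturated ring carbon. Like the group it replaces, the entering group is a neutral amide-type substituent; the basic amine of compound 1 is not restored. The step from compound 1 to compound 2 therefore speaks against any return toward the number of compound 1, while nothing in the measured set distinguishes one neutral substituent from another at this place. Compound 3 is consequently expected to stay near compound 2, with a step of a 1.5-fold higher number from compound 2 to compound 3 (0.18 log units; within the scatter), and is estimated at 60 nM in this assay, within 12 nM to 300 nM.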

Compound 3, inhibition constant: 2 nM
The estimate for compound 3 lay 30-fold (1.48 log units) above the measured number; measured number below the stated range.
By their numbers in this assay, from the lowest: compound 1; then compound 3; then compound 2.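

In this assay, the step of a 20-fold lower number from compound 2 to compound 3 (1.30 log units; beyond the scatter) shows that this place, on a saturated chain carbon bound to a saturated ring carbon, separates two groups that both carry no net charge: ((1-hydroxy-1-methylethyl)carbonyl)amino gives a much lower number than carbamoyl(methyl)amino. Absence of a net charge on the entering group therefore does not fix the number near that of compound 2, and the step of an 8.0-fold higher number from compound 1 to compound 3 (0.90 log units; beyond the scatter) is modest beside the large step of a 160-fold higher number from compound 1 to compound 2 (2.20 log units; beyond the scatter) while still lying beyond the scatter, so (2-methoxyethyl)amino keeps the lowest number of the three. No measurement shown here accounts for the difference between these groups.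

The change from compound 2 to compound 3 replaces the carbamoyl, the methyl on the nitrogen and the hydroxy-bearing carbon all at once, so the compounds shown cannot assign the lower number to any one of these parts. Plain acetylamino, or carbamoylamino without the methyl, would separate these parts, while a carboxylic acid at the same place remains an open case.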